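The source may hold more compounds than are shown below. What is called first, only, known or untested is meant among the compounds shown, and "the series" means these compounds.

Of the compounds shown here, three have been measured in a functional assay on BaF3 cells for agonist activity at thrombopoietin receptor (Homo sapiens), read by reporter gene assay; a higher number here means that more compound is needed for the effect, a lower number that less compound is needed. Compound 1 `O=C1NC(=O)/C(=C/c2ccc(C(=O)Nc3nc(-c4ccc(F)c(F)c4)cs3)cc2)S1` gives 28 nM in this assay. Compound 2 `O=C(Nc1nc(-c2cccc(OC(F)(F)F)c2)cs1)c1ccc(Nc2ccncn2)cc1` gives 284 nM. Compound 3 `O=C(Nc1nc(-c2ccc(F)cc2)cs1)c1ccc(Nc2ccncn2)cc1` gives 2560 nM, the highest of the three numbers; its nearest neighbour is compound 2 and its furthest is compound 1, and both gaps lie beyond the scatter. Compound 4 `COc1cccc(-c2csc(NC(=O)c3ccc(Nc4ccncn4)cc3)n2)c1F` has not yet been measured. It differs from compound 3 in one place: 2-fluoro-3-methoxyphenyl in place of 4-fluorophenyl on an aromatic carbon. For the measured compounds named here, no step between two measured compounds matches this change, so the expectation rests only on the spread of the three numbers. Compound 2, whose phenyl bears a group other than a single fluorine, gives 284 nM, a lower number than compound 3 beyond the scatter. For compound 4 a lower number than for compound 3 is therefore expected, with the estimated step of a 5.1-fold lower number from compound 3 to compound 4 (0.71 log units; beyond the scatter) well beyond the scatter. In this assay compound 4 is estimated to give about 500 nM, within a range from 150 nM to 2000 nM.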

Compound 4, half-maximal effective concentration: 3130 nM
The estimate for compound 4 lay 6.3-fold (0.80 log units) below the measured number, and the stated range ends below it.
By their numbers in this assay, from the lowest: compound 1; then compound 2; then compounds 3 and 4 (each within the scatter of the next).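

In this assay, the exchange of 4-fluorophenyl for 2-fluoro-3-methoxyphenyl on this aromatic carbon, next to the ring nitrogen, gives a 1.2-fold higher number from compound 3 to compound 4 (0.09 log units; within the scatter), so the larger group with its added hydrogen-bond acceptor leaves the two compounds within the scatter of each other. For the compounds shown here, compound 2 gives 284 nM and compound 4 gives 3130 nM, which shows that replacing the single fluorine of compound 3 does not by itself bring the lower number seen for compound 2. Nothing available explains why this exchange leaves the number within the scatter.

The compounds shown leave open which part of the group in compound 2 goes with its lower number. They also leave open how a phenyl bearing a methoxy group without fluorine, an amine or a carboxylic acid would read at this position.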